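Trimming the Chain of Compound 1

The source may hold more compounds than are shown below. What is called first, only, known or untested is meant among the compounds shown, and "the series" means these compounds.

In a physicochemical assay for lipophilicity, in phosphate buffer, measured as octanol-water partition, at pH 11.5 (on this read-out higher numbers stand for higher lipophilicity and lower numbers for lower lipophilicity), compound 1 (`CCCCC(CC)CNC(=N)NC(=N)Nc1ccc(Cl)cc1`) reads 4.93 and stands lowest of the two compounds measured. Compound 2 (`CCCSc1ccc(NC(=N)NC(=N)NCCCCCCNC(=N)NC(=N)Nc2ccc(SCCC)cc2)cc1`) reads 6.58 on the same scale. The gap between these two compounds lies beyond the scatter. Compound 3 (`CCCNC(=N)NC(=N)Nc1ccc(Cl)cc1`) has not yet been measured. It carries ethyl in place of 1-ethylpentyl on a saturated chain carbon bound to an amine nitrogen. Going by the values given here, no measured pair shows such a change, so the expectation rests on the structural change alone: a fall in this assay beyond the scatter. The expected step is a number 2.23 log units lower from compound 1 to compound 3 (beyond the scatter) by this estimate. The estimated value for compound 3 is 2.7 within an expected range of 2.1 to 3.3 until a measurement is available.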

Compound 3, partition coefficient: 2.63
Estimate against measurement, compound 3: 0.07 log units above; the range from low to high includes it.
By their numbers in this assay, from the lowest: compound 3; then compound 1; then compound 2.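

In this assay, going by these compounds alone, ethyl in place of 1-ethylpentyl on a saturated chain carbon bound to an amine nitrogen gives a number 2.30 log units lower from compound 1 to compound 3 (beyond the scatter), the first change in one place that can be read. It shows that this position alone can move the read-out by a large step while the rest of compound 1 stays the same. No measurement at hand explains the size of this step.

Only ethyl and 1-ethylpentyl are shown at this position, so it remains open whether a butyl chain would fall between them. As far as these compounds go, how a hydroxyethyl or cyclohexyl group would read there is also open.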